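The source may report more compounds than this note shows. Statements on the series, on what has been measured and on what is new or still open speak of the compounds shown alone.

Measured so far, in a functional assay on MOLT-4 cells (Homo sapiens) for antiproliferative activity, read by MTT assay, with a stated time of 72 h; on this read-out lower numbers stand for stronger inhibition and higher numbers for weaker inhibition:
- Compound 1 `O=C1NC(=O)/C(=C/C2=Cc3ccccc3OC2)N1` gives 21300 nM.
- Compound 2 `CN1C(=O)S/C(=C\C2=Cc3ccccc3OC2)C1=O` gives > 100000 nM; this is a limit of the assay, not a number.
- Compound 3 `O=C1NC(=S)S/C1=C\C1=Cc2cc(Br)ccc2OC1` gives 38200 nM.

Among the two values that are numbers, compound 1 stands lowest, and compound 3 lies closest to it, within the usual scatter of this assay, so no order can be read from those two. One of the three results sits at the limit of > 100000 nM in this assay, at which 1 of the 3 values shown sits.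

Compound 4 `O=C1NC(=O)/C(=C/C2=Cc3cc(Br)ccc3OC2)N1` has not yet been measured. It differs from compound 1 in one place: bromo in place of hydrogen on an aromatic carbon. For the measured compounds named here, no measured pair shows this same change on the same core, so the size of the step is open. Compound 3 carries the same bromo group on a different core and gives a number close to that of compound 1, which is the only hint available. The step from compound 1 to compound 4 is expected to be small, a 1.0-fold higher number from compound 1 to compound 4 (0.01 log units; within the scatter), with neither direction favoured. Compound 4 is therefore estimated at 22000 nM, with a range from 8000 nM to 60000 nM.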

Compound 4, half-maximal inhibitory concentration: 77500 nM
Estimate against measurement, compound 4: 3.5-fold (0.55 log units) below; the measured number lies above the stated range.
By their numbers in this assay, from the lowest: compounds 1 and 3 (each within the scatter of the next); then compound 4. At a limit, above all of these: compound 2.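

In this assay, placing bromo in place of hydrogen on the shared core gives a 3.6-fold higher number from compound 1 to compound 4 (0.56 log units; beyond the scatter). For the compounds shown here, this is the first direct reading of the change: on this core, at this aromatic carbon, meta to a fused ring and para to a fused ring, bromo goes with modestly weaker inhibition rather than leaving the number unchanged, something compound 3 could not show, as it carries bromo on a different core. Nothing measured here accounts for the direction or size of this step.

As far as these compounds go, whether chloro, methoxy or an amine at the same carbon would move the number in the same way remains open. A single pair also leaves open whether bromo on another aromatic carbon, or on another core, would give a similar step.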